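Swapping cyclopropyl for 4-fluorophenyl on the carbonyl

A few compounds are considered here, and "the series" means these few. Any claim that something is new, unique, unknown or untested is made for them only; others in the source may bear on it.

compound 1 `Cc1ccc(C(=O)N2CCN(c3nc(=O)c4cc(C(F)(F)F)cc([N+](=O)[O-])c4s3)CC2)cc1`: > 125000 nM, a limit
compound 2 `O=C(c1ccccc1Cl)N1CCN(c2nc(=O)c3cc(C(F)(F)F)cc([N+](=O)[O-])c3s2)CC1`: > 125000 nM, a limit
compound 3 `O=C(C1CC1)N1CCN(c2nc(=O)c3cc(C(F)(F)F)cc([N+](=O)[O-])c3s2)CC1`: > 125000 nM, a limit

All three readings in an ADME assay on Vero cells (Chlorocebus sabaeus) for cytotoxicity, read by MTT assay, with a stated time of 72 h (a lower number here means that less compound is tolerated, a higher number that more compound is tolerated), are limits and not numbers, and compound 3 stands with the others: the limit of > 125000 nM in this assay, at which 3 of the 3 values shown sit. Compound 4 `O=C(c1ccc(F)cc1)N1CCN(c2nc(=O)c3cc(C(F)(F)F)cc([N+](=O)[O-])c3s2)CC1` differs from compound 3 as follows: 4-fluorophenyl in place of cyclopropyl on a carbonyl carbon. In short, 4-fluorophenyl sits in place of cyclopropyl on a carbonyl carbon. Two measured steps change the same place: a step that the two limits leave unreadable from compound 1 to compound 3 and a step that the two limits leave unreadable from compound 2 to compound 3. Neither gives a size or a direction. A step beyond the scatter is not expected in this assay, since compound 1, carrying 4-methylphenyl, gives > 125000 nM. The expected step is a step that the limit leaves unreadable from compound 3 to compound 4. For compound 4 the estimated value is 140000 nM, expected within 70000 nM to 250000 nM.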

Compound 4, half-maximal cytotoxic concentration: > 125000 nM
Compound 4: no number, only a limit (the forecaster's own chance of this, stated with the estimate: 80%); the middle value lies beyond the limit too.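

Compound 4, like compound 1, compound 2 and compound 3, gives only a limit in this assay, so no step among these compounds can be read. Going by these compounds, whether the group on the carbonyl carbon shifts the read-out in this assay at all remains open.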